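Lengthening the hydroxy-bearing chain of compound 1

A few compounds are considered here, and "the series" means these few. Any claim that something is new, unique, unknown or untested is made for them only; others in the source may bear on it.

Compound 1 `CCOC(=O)c1cnn(CC(O)CC)c1NC(=O)NC(C)C` is read in a functional assay on cells (Neutrophil, Homo sapiens) for inhibition, with a stated time of 10 min (on this read-out lower numbers stand for stronger inhibition and higher numbers for weaker inhibition), only as a limit of the assay, > 10 nM. Compound 2 `CCOC(=O)c1cnn(CC(O)CC)c1NC(=O)Nc1ccc(F)cc1` gives 3.2 nM in this assay. Compound 3 `CCOC(=O)c1cnn(CC(O)CC)c1NC(=O)NCc1ccccc1` is likewise reported only as a limit, > 10 nM. Two of the three values therefore sit at the limit of > 10 nM in this assay, at which 2 of the 3 values shown sit. Compound 4 `CCCC(O)Cn1ncc(C(=O)OCC)c1NC(=O)NC(C)C` differs from compound 1 by methyl in place of hydrogen on a saturated chain carbon, three bonds along the chain from an oxygen on a saturated carbon. The measured steps, an at least 3.1-fold lower number from compound 1 to compound 2 (0.49 log units; beyond the scatter) and an at least 3.1-fold higher number from compound 2 to compound 3 (0.49 log units; beyond the scatter), change the group on the amide-type nitrogen rather than the chain, so none of them bears on this change, and with compound 1 given only as a limit no step beyond the scatter can be foreseen. Compound 4 is expected to stay near that limit, with a step that the limit leaves unreadable from compound 1 to compound 4, giving an estimate of 30 nM within 10 nM to 100 nM.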

Compound 4, half-maximal inhibitory concentration: 20 nM
Beside the measured number, compound 4's estimate is 1.5-fold (0.18 log units) above it, and the stated range covers the measured number.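

No step can be read from compound 1 to compound 4, because compound 1 is reported only as a limit: the limit of > 10 nM in this assay, at which 2 of the 4 values shown sit. On these data alone, whether methyl in place of hydrogen on this chain shifts the inhibition at all stays open.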